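The source may report more compounds than this note shows. Statements on the series, on what has been measured and on what is new or still open speak of the compounds shown alone.

Measured compounds:
- compound 1 `COC(=O)c1cncc(NS(=O)(=O)c2cc(Cl)ccc2OC)c1`: > 20000 nM
- compound 2 `COc1ccc(C(F)(F)F)cc1S(=O)(=O)Nc1cccnc1`: 3010 nM

In an assay on isolated protein for inhibition of alkaline phosphatase, tissue-nonspecific isozyme (Homo sapiens) (a higher number here means a weaker inhibitor, a lower number a stronger inhibitor), compound 1 gives only a limit, > 20000 nM, not a number. In this assay compound 2 gives 3010 nM. Compound 1 therefore stands at the limit of > 20000 nM in this assay, at which 1 of the 2 values shown sits, and nothing more than that can be read from it. Going by the values given here, compound 1 and compound 2 differ in more than one place, so their two values show only that compound 2 returns a number where compound 1 does not; no measured step links them.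

Compound 3 `COc1ccc(Cl)cc1S(=O)(=O)Nc1cncc(C(N)=O)c1` differs from compound 1 in one place: amino in place of methoxy on a carbonyl carbon. Among the compounds with values here, no measured pair in the set carries this change, so its size in this assay is not known from the data. The expectation is a step no larger than the scatter, with the direction open, given that compound 1 sits at a limit; the step expected is a number no higher from compound 1 to compound 3 (the limit leaves the size open). Compound 3 is accordingly estimated at 20000 nM in this assay, with a range from 5000 nM to 60000 nM, and a fair chance that only a limit is again returned.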

Compound 3, half-maximal inhibitory concentration: 105 nM
The estimate for compound 3 lay 190-fold (2.28 log units) above the measured number, and the stated range ends above it.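

The change from methoxycarbonyl to carbamoyl is the only single-place change shown here, and in this assay it gives an at least 190-fold lower number from compound 1 to compound 3 (2.27 log units; beyond the scatter). The substituent on this carbonyl carbon therefore matters strongly in this series: with the rest of the core unchanged, the exchange of methoxy for amino alone separates a compound with no measurable number from compound 3 at 105 nM. The true size of the step stays open, as the value for compound 1 is a limit of the assay and not a number: the limit of > 20000 nM in this assay, at which 1 of the 3 values shown sits.

The compounds shown do not separate the loss of the methoxy from the gain of the amino, and a carboxylic acid, a methylamino or a dimethylamino on the same carbonyl carbon, or a nitrile in place of the whole carbamoyl, would bear on which of the two counts. They also leave open whether carbamoyl gives a similar step on other cores, such as a trifluoromethyl analogue related to compound 2, which carries no carbonyl group and gives 3010 nM.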